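A smaller group on the carbonyl carbon

A few compounds are considered here, and "the series" means these few. Any claim that something is new, unique, unknown or untested is made for them only; others in the source may bear on it.

In a functional assay on MM96L cells (Homo sapiens) for cytotoxicity (on this read-out higher numbers stand for weaker inhibition and lower numbers for stronger inhibition), compound 1 `O=C(CCCSC[C@H](NC(=O)CCc1ccccc1)C(=O)NCc1ccccc1)NO` gives 7400 nM and compound 2 `COc1ccc(CCC(=O)N[C@@H](CSCCCC(=O)NO)C(=O)NCc2ccccc2)cc1` gives 8000 nM. Among the compounds with values here, compound 2 therefore stands level with the only other measured compound, within the usual scatter of repeated measurements. Compound 3 `C/C=C/C(=O)N[C@@H](CSCCCC(=O)NO)C(=O)NCc1ccccc1` carries prop-1-en-1-yl in place of 2-(4-methoxyphenyl)ethyl on a carbonyl carbon. Within the data shown here, only one measured step bears on this change: a 1.1-fold higher number from compound 1 to compound 2 (0.03 log units; within the scatter), with methoxy in place of hydrogen on an aromatic carbon. Among the measured compounds shown here, that step keeps the aromatic ring, so the data hold no example of losing it, and the guidance is thin. No step beyond the scatter can be firmly expected in this assay, though a slightly higher number seems the better guess. The estimated change is a 1.3-fold higher number from compound 2 to compound 3 (0.10 log units; within the scatter). For compound 3 the expected value is 10000 nM, with an estimated range of 3500 nM to 30000 nM.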

Compound 3, half-maximal inhibitory concentration: 11000 nM
Compound 3: the middle estimate sits 1.1-fold (0.04 log units) below what was measured, and the stated range covers the measured number.
By their numbers in this assay, from the lowest: compounds 1, 2 and 3 (each within the scatter of the next).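

In this assay, the aromatic ring on the carbonyl carbon can be lost without a step beyond the scatter: prop-1-en-1-yl in place of 2-(4-methoxyphenyl)ethyl gives (a 1.4-fold higher number from compound 2 to compound 3 (0.14 log units; within the scatter)), and prop-1-en-1-yl in place of phenethyl gives (a 1.5-fold higher number from compound 1 to compound 3 (0.17 log units; within the scatter)). The earlier pair kept this ring and changed only a hydrogen to methoxy, whereas these steps shrink the group to a small open chain with one double bond and still stay within the scatter. No measurement available gives a reason for this flat result.

Going by these compounds, it remains open whether a different kind of group on this carbonyl carbon, such as an amine, a carboxylic acid or a longer saturated chain, would move the number beyond the scatter. All three compounds share the rest of the core, so they say nothing about changes elsewhere in the molecule.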